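The compounds below may be only part of what the source reports. "The series", "measured", "known", "first", "only" and "open" are said of these compounds alone.

Of the compounds shown here, two carry numbers so far. Compound 1 `O=C(O)CCc1ccc(C#Cc2cccc([N+](=O)[O-])c2)cc1` gives 58.9 nM in an in vitro functional assay on 1321-N1 cells for agonist activity at Free fatty acid receptor 1 (Homo sapiens), read by fluorescence (a lower number here means that less compound is needed, a higher number that more compound is needed for the effect), the lowest of the two. Compound 2 `Cc1cccc(C#Cc2ccc(OCC(=O)O)cc2)c1` gives 513 nM in this assay, a higher number that lies beyond the scatter. Compound 3 `Nc1cccc(C#Cc2ccc(CCC(=O)O)cc2)c1` has not been measured; it differs from compound 1 by amino in place of nitro on an aromatic carbon. Among the compounds with values here, no measured pair shows this same change, so its effect is not known from the series. A modest rise in the number is expected, estimated as a 2.5-fold higher number from compound 1 to compound 3 (0.41 log units; beyond the scatter). Compound 3 is expected to give about 150 nM, with a range from 50 nM to 500 nM.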

Compound 3, half-maximal effective concentration: 1100 nM
Beside the measured number, compound 3's estimate is 7.3-fold (0.87 log units) below it; the measured number lies above the stated range.
By their numbers in this assay, from the lowest: compound 1; then compound 2; then compound 3.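

Within the data shown here, on an aromatic carbon meta to a large group, amino in place of nitro gives a 19-fold higher number from compound 1 to compound 3 (1.27 log units; beyond the scatter) in this assay, the first reading of a change at this position. The group on this carbon therefore has a large effect on the number, and nitro is the better of the two groups compared here. No measurement at hand accounts for the size of this step.

Still open, from the compounds shown here alone, is where a nitrile or an acetamide on this same carbon would fall relative to compound 1 and compound 3. Also open, going by these compounds, is whether the step carries over to the oxyacetic acid side chain of compound 2.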